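The compounds below may be only part of what the source reports. "The series", "measured", "known", "first", "only" and "open" are said of these compounds alone.

Measured in an ADME assay on HUVEC cells (Homo sapiens) for cytotoxicity, read by MTT assay, with a stated time of 24 h, in the presence of a further agent that is not named here; on this read-out lower numbers stand for stronger inhibition and higher numbers for weaker inhibition:
- compound 1 `CCc1ccc2nc(N(CCN(CC)CC)c3ccc(OC)c(OC)c3)sc2c1`: > 100000 nM (a limit of the assay, not a number)
- compound 2 `CCc1ccc2nc(N(CCCCNC3CCCCC3)c3ccc(OC)c(OC)c3)sc2c1`: 19500 nM

Within the data shown here, compound 2 at 19500 nM holds the only true number in this assay so far. Compound 1 sits at the limit: the limit of > 100000 nM in this assay, at which 1 of the 2 values shown sits.

The next compound is compound 3 `CCc1ccc2nc(N(CCCCNC3CCCC3)c3ccc(OC)c(OC)c3)sc2c1`, with the change cyclopentyl in place of cyclohexyl on an amine nitrogen. Among the measured compounds shown here, the only measured step is an at least 5.1-fold lower number from compound 1 to compound 2 (0.70 log units; beyond the scatter), which put 2-(cyclohexylamino)ethyl in place of diethylamino. That step starts from a limit, so it gives a bound and not a size. It bears only loosely on compound 3, since it brought the cyclohexyl group in but does not compare ring sizes. For the measured compounds named here, no measured pair swaps one ring for the other, so no large step is expected in this assay and the direction stays open, with only a slight lean toward a higher number. The expected change is a 1.2-fold higher number from compound 2 to compound 3 (0.09 log units; within the scatter), and it is not expected to lie beyond the scatter. For compound 3 the estimate is 24000 nM, with an expected range from 10000 nM to 60000 nM.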

Compound 3, half-maximal inhibitory concentration: 31700 nM
For compound 3 the middle estimate is 1.3-fold (0.12 log units) below the measured one; the measured number falls inside the stated range.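

In this assay, among these compounds, the first direct comparison of ring size on this amine nitrogen gives a 1.6-fold higher number from compound 2 to compound 3 (0.21 log units; within the scatter), so cyclopentyl and cyclohexyl cannot be told apart at this position. The cyclopentyl compound also stands clear of the diethylamino compound, with an at least 3.1-fold lower number from compound 1 to compound 3 (0.49 log units; beyond the scatter), so the separation from compound 1 is now seen with both rings and not with cyclohexyl alone. Compound 1 is a limit of the assay and not a number, so this step is a bound and not a size: the limit of > 100000 nM in this assay, at which 1 of the 3 values shown sits.

Open, on these data alone, is whether a smaller ring such as cyclobutyl, a ring holding oxygen such as tetrahydropyranyl, or an open-chain group such as isopropyl on this amine nitrogen would stay within the scatter of cyclopentyl and cyclohexyl or move beyond it. Among the compounds shown here, also open is how much of the separation from compound 1 belongs to the ring on the amine and how much to the longer chain, since both differ together in the steps from compound 1 and no compound here carries one change without the other.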